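The compounds below may be only part of what the source reports. "The series", "measured", "known", "first", "only" and "open" are said of these compounds alone.

Working notes on the series. All three measured compounds carry the same core, differing only in the aromatic group on it. In a functional assay on MCF7 cells (Homo sapiens) for cytotoxicity, read by MTT assay, with a stated time of 48 h (a higher number here means a weaker inhibitor, a lower number a stronger inhibitor), compound 1 `Cc1ncc([N+](=O)[O-])n1CCSc1nnc(-c2ccccc2N)o1` gives 20100 nM; compound 2 `COc1ccc(-c2nnc(SCCn3c([N+](=O)[O-])cnc3C)o2)c(O)c1` gives 21800 nM; compound 3 `COc1cc(-c2nnc(SCCn3c([N+](=O)[O-])cnc3C)o2)cc(OC)c1OC` gives 30600 nM. Compound 1 sits among these three with its number within the scatter of both compound 2 and compound 3, so no ranking among them can be drawn.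

Compound 4 `Cc1ncc([N+](=O)[O-])n1CCSc1nnc(-c2ccnc(Cl)c2)o1` has not yet been measured in this assay. Relative to compound 1 the change is 2-chloropyridin-4-yl in place of 2-aminophenyl on an aromatic carbon. Going by the values given here, no measured pair shows what such a change does, and the three measured numbers hardly spread, so the step from compound 1 to compound 4 is expected to remain within the scatter, a 1.2-fold higher number from compound 1 to compound 4 (0.09 log units; within the scatter). For compound 4 the expected value is 25000 nM, within a range from 8000 nM to 80000 nM.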

Compound 4, half-maximal inhibitory concentration: 40500 nM
Estimate against measurement, compound 4: 1.6-fold (0.21 log units) below; the measured number falls inside the stated range.
By their numbers in this assay, from the lowest: compounds 1, 2, 3 and 4 (each within the scatter of the next).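

Going by these compounds alone, compound 4 gives the first one-place step: in this assay the exchange of 2-aminophenyl for 2-chloropyridin-4-yl on this aromatic carbon amounts to a 2.0-fold higher number from compound 1 to compound 4 (0.30 log units; within the scatter) and sets no order between the two. This position therefore carries a ring with a hetero atom, a chlorine and no hydrogen-bond donor while the number stays within the scatter. No supporting data bear on this step. From the compounds shown here alone, it remains open whether a morpholine or a carboxylic acid on this carbon would move the number beyond the scatter. An unsubstituted phenyl would give a reference for the aromatic groups shown.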